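What compound 1 loses with its (1-bromoethenyl)carbonyl group

The source may hold more compounds than are shown below. What is called first, only, known or untested is meant among the compounds shown, and "the series" means these compounds.

Among the compounds with values here, in a functional assay on MOLT-4 cells (Homo sapiens) for antiproliferative activity, with a stated time of 48 h (a higher number here means a weaker inhibitor, a lower number a stronger inhibitor), compound 1 (`C=C(Br)C(=O)Nc1ccc(/C=C/C(=O)c2ccccc2)cc1`) gives 3100 nM, the higher of the two numbers measured so far. Its methoxy counterpart, compound 2 (`C=C(Br)C(=O)Nc1ccc(/C=C/C(=O)c2ccc(OC)cc2)cc1`), gives 1300 nM. Within the data shown here, the only measured step, a 2.4-fold lower number from compound 1 to compound 2 (0.38 log units; beyond the scatter), comes with methoxy in place of hydrogen on an aromatic carbon, and it is modest.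

Compound 3 (`Nc1ccc(/C=C/C(=O)c2ccccc2)cc1`) is still unmeasured. It carries hydrogen in place of (1-bromoethenyl)carbonyl on a nitrogen on an aromatic ring. The measured step bears on this only loosely, since it concerns a different place in the molecule. Both measured compounds keep the (1-bromoethenyl)carbonyl group, so the data offer no direct measure of its loss. Compound 3 keeps the core of compound 1 but loses that whole group, so a larger change than the modest methoxy step is expected, towards a higher number and a weaker inhibitor. The expected step is a 4.8-fold higher number from compound 1 to compound 3 (0.68 log units; beyond the scatter). The estimate for compound 3 is 15000 nM, with an expected range from 5000 nM to 50000 nM.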

Compound 3, half-maximal inhibitory concentration: 10000 nM
The estimate for compound 3 lay 1.5-fold (0.18 log units) above the measured number; the measured number falls inside the stated range.
By their numbers in this assay, from the lowest: compound 2; then compound 1; then compound 3.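

In this assay, within the data shown here, the step at the nitrogen is the first reading of this position: taking away the (1-bromoethenyl)carbonyl group and leaving hydrogen gives a 3.2-fold higher number from compound 1 to compound 3 (0.51 log units; beyond the scatter). The group therefore goes with a lower number on this core, yet the change is modest, and the core of compound 1 with a plain amino group still gives a number in this assay. Nothing shown accounts for the size of this step or says how the group acts.

The group leaves as a whole, so the compounds shown cannot separate the contributions of its bromine, its double bond and its carbonyl; an acetyl group or an ethenylcarbonyl group without the bromine on the same nitrogen would begin to divide them. On these data alone, it also stays open whether the methoxy step seen with the (1-bromoethenyl)carbonyl group present would carry over to the amino compound, and whether a chlorine in place of the bromine would keep the number of compound 1.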